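This account rests on a few compounds, and the source may have more. Where it says the series, first, only, none or still open, it means among the compounds named here.

Two compounds of this series share a core and differ only in the aromatic group attached to one carbon of that core. Compound 1 `CS(=O)(=O)Nc1cccc(-c2cc(C(O)(C(F)(F)F)C(F)(F)F)cnc2N2CCN(S(=O)(=O)c3ccc(N)nc3)CC2)c1` gives 81 mL.min-1.g-1 in an ADME assay (liver) for metabolic stability, with Liver microsome (Rattus norvegicus) as the target, using microsomes and NADPH, with a stated time of 30 min, tested at 1 uM; on this read-out higher numbers stand for fast clearance and lower numbers for slow clearance. Compound 2 `COc1cncc(-c2cc(C(O)(C(F)(F)F)C(F)(F)F)cnc2N2CCN(S(=O)(=O)c3ccc(N)nc3)CC2)c1` gives 58 mL.min-1.g-1 in this assay. The step of a 1.4-fold lower number from compound 1 to compound 2 (0.15 log units; within the scatter) is the only measured comparison available, and it lies within the usual scatter, so on the numbers shown compound 2 and compound 1 cannot be told apart with confidence.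

Compound 3 `Nc1ccc(S(=O)(=O)N2CCN(c3ncc(C(O)(C(F)(F)F)C(F)(F)F)cc3-c3cc4ccccc4s3)CC2)cn1` carries the change 1-benzothiophen-2-yl in place of 5-methoxypyridin-3-yl on an aromatic carbon at the same place on the core where compound 1 and compound 2 already differ. Among the measured compounds shown here, the one measured step at this position, a 1.4-fold lower number from compound 1 to compound 2 (0.15 log units; within the scatter), was small, which suggests that swapping the aromatic group here need not move the clearance much. The group entering is, however, unlike either group seen so far, so the evidence bears on compound 3 only loosely.

For compound 3 a number of 110 mL.min-1.g-1 is expected, with a likely range from 55 mL.min-1.g-1 to 220 mL.min-1.g-1. This corresponds to an expected step of a 1.9-fold higher number from compound 2 to compound 3 (0.28 log units; within the scatter), which could still fall within the scatter.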

Compound 3, intrinsic clearance in microsomes: 315 mL.min-1.g-1
Compound 3: middle estimate off by 2.9-fold (0.46 log units), on the low side, outside the stated range (above it).
By their numbers in this assay, from the lowest: compounds 2 and 1 (each within the scatter of the next); then compound 3.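

The aromatic group on this carbon can clearly matter for clearance: in this assay, 1-benzothiophen-2-yl in place of 5-methoxypyridin-3-yl gives a 5.4-fold higher number from compound 2 to compound 3 (0.73 log units; beyond the scatter) and so moves the number well beyond what the earlier pair showed. The comparison with the other earlier group points the same way, with a 3.9-fold higher number from compound 1 to compound 3 (0.59 log units; beyond the scatter) for 1-benzothiophen-2-yl in place of 3-(methanesulfonamido)phenyl. Thus, among these three compounds, the group in compound 3 stands apart from the two earlier groups, which cannot be told apart from each other, but no measurement here explains the higher clearance.

On these data alone, the entering group differs from 5-methoxypyridin-3-yl in several ways at once, so it remains open whether the higher number goes with the sulfur-containing five-membered ring, the fused carbon-only six-membered ring, or the two together. A plain thiophen-2-yl or phenyl group at this carbon, or a 1-benzothiophen-2-yl group carrying a carboxylic acid or an amine, would help separate these parts of the change.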